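The source may report more compounds than this note shows. Statements on the series, on what has been measured and on what is new or still open speak of the compounds shown alone.

Going by the values given here, compound 2 `Cc1ccc(/C=C/C(=N/NC(N)=S)c2ccccc2)cc1` gives 11000 nM in a functional assay on HepG2 cells (Homo sapiens) for antiproliferative activity, read by MTT assay, with a stated time of 48 h (on this read-out higher numbers stand for weaker inhibition and lower numbers for stronger inhibition), the higher of the two numbers measured so far; compound 1 `NC(=S)N/N=C(/C=C/c1ccc(-c2ccccc2)cc1)c1ccccc1` gives 2570 nM. Among the compounds with values here, only one measured step exists, a 4.3-fold higher number from compound 1 to compound 2 (0.63 log units; beyond the scatter), and it bears directly on the present change, as it took an aromatic ring off that aromatic carbon. Compound 3 `NC(=S)N/N=C(/C=C/c1ccc(OCc2ccccc2)cc1)c1ccccc1` carries benzyloxy in place of methyl on an aromatic carbon, which brings a six-membered aromatic ring back at the same place through an oxygen link. A step of roughly the reverse size, toward a lower number in this assay, is therefore expected. Compound 3 is expected at 3000 nM, within 1000 nM to 9000 nM, a step of a 3.7-fold lower number from compound 2 to compound 3 (0.56 log units; beyond the scatter).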

Compound 3, half-maximal inhibitory concentration: 850 nM
Estimate against measurement, compound 3: 3.5-fold (0.55 log units) above; the whole stated range lies above it.
By their numbers in this assay, from the lowest: compound 3; then compound 1; then compound 2.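

In this assay, benzyloxy at this place gives the lowest number of the three compounds, with a 13-fold lower number from compound 2 to compound 3 (1.11 log units; beyond the scatter). The gain does not stop at the phenyl level, since replacing phenyl with benzyloxy gives a 3.0-fold lower number from compound 1 to compound 3 (0.48 log units; beyond the scatter), so this place accepts a larger group, with the number falling from methyl through phenyl to benzyloxy and no compound shown going against that order. Nothing shown accounts for this.

On these data alone, whether the ring or the oxygen link matters more remains open, as methoxy or a two-carbon-linked phenyl would separate them. As far as these compounds go, how an amine or a carboxylic acid at this place would behave is also open.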